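Adding a Methoxy Group to a Weak Growth Inhibitor

The compounds below may be only part of what the source reports. "The series", "measured", "known", "first", "only" and "open" are said of these compounds alone.

Compound 1 `CC1=CC[C@H](C(C)(C)NC(=S)N/N=C/c2ccc(O)cc2)CC1` and compound 3 `CC1=CC[C@H](C(C)(C)NC(=S)N/N=C(\C)c2ccccc2)CC1` are close relatives; the difference between the two cores is not broken down here. In a functional assay on OVCAR-3 cells (Homo sapiens) for inhibition, read by sulforhodamine B assay, with a stated time of 48 h (a higher number here means a weaker inhibitor of growth, a lower number a stronger inhibitor of growth), compound 1 gives only a limit, > 100000 nM. Compound 3 also gives only a limit in this assay, > 100000 nM. Compound 2 `COc1cc(/C=N/NC(=S)NC(C)(C)[C@H]2CC=C(C)CC2)ccc1O` carries methoxy in place of hydrogen on an aromatic carbon, and in this assay compound 2 gives 53500 nM, which is an at least 1.8-fold lower number from compound 1 to compound 2 (0.27 log units; that floor lies within the scatter). Compound 4 `COc1ccc(/C(C)=N/NC(=S)NC(C)(C)[C@H]2CC=C(C)CC2)cc1` carries the same kind of change, (methoxy in place of hydrogen on an aromatic carbon), though here the place is para to a large group, whereas in compound 2 it is ortho to a hydroxy group and meta to a large group. Resting on an at least 1.8-fold lower number from compound 1 to compound 2 (0.27 log units; that floor lies within the scatter), the expected step is an at least 1.1-fold lower number from compound 3 to compound 4 (0.04 log units; that floor lies within the scatter). In this assay compound 4 is estimated at 90000 nM, between 30000 nM and 300000 nM.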

Compound 4, concentration for 50% growth inhibition: 74900 nM
The estimate for compound 4 lay 1.2-fold (0.08 log units) above the measured number; the measured number falls inside the stated range.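

Going from phenyl to 4-methoxyphenyl in this assay gives an at least 1.3-fold lower number from compound 3 to compound 4 (0.12 log units; that floor lies within the scatter). Set beside the earlier step, the result stays open: the same change on two cores in this assay, an at least 1.8-fold lower number (0.27 log units; that floor lies within the scatter) from compound 1 to compound 2 and an at least 1.3-fold lower number (0.12 log units; that floor lies within the scatter) from compound 3 to compound 4; the limit leaves it open whether they differ. The two steps fit the change carrying over from one core to the other, but they do not show a true drop on either core or its size, because each starting compound gives only a limit: the limit of > 100000 nM in this assay, at which 2 of the 4 values shown sit.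

The compounds shown leave open whether the methoxy step would keep its size on a core whose starting compound gives a measured number rather than a limit. They also leave open how an amine or a carboxylic acid in place of that hydrogen would read in this assay.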